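This account rests on a few compounds, and the source may have more. Where it says the series, first, only, none or still open, it means among the compounds named here.

Measured in a functional assay on A549 cells (Homo sapiens) for cytotoxicity, with a stated time of 48 h; a higher number here means a weaker inhibitor, a lower number a stronger inhibitor:
- compound 1 `C[S+]([O-])/C=C/c1cc(=O)c2ccccc2o1`: 1900 nM
- compound 2 `CC(C)CC(=O)Oc1ccc2oc(/C=C/[S+](C)[O-])cc(=O)c2c1`: 2300 nM
- compound 3 `C[S+]([O-])/C=C/c1cc(=O)c2cc(F)ccc2o1`: 2100 nM

Compound 3 cannot be separated from the other two compounds on these numbers. The data show a 1.1-fold higher number from compound 1 to compound 3 (0.04 log units; within the scatter) and a 1.1-fold lower number from compound 2 to compound 3 (0.04 log units; within the scatter).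

Compound 4 `C[S+]([O-])/C=C/c1cc(=O)c2cc(C#N)ccc2o1` has not yet been measured. It has cyano in place of fluoro on an aromatic carbon. Within the data shown here, no measured compound carries cyano, so the evidence is indirect. Three steps involve a change at this aromatic carbon. Fluoro in place of hydrogen gave a 1.1-fold higher number from compound 1 to compound 3 (0.04 log units; within the scatter), while (isobutylcarbonyl)oxy in place of hydrogen gave a 1.2-fold higher number from compound 1 to compound 2 (0.08 log units; within the scatter). Exchanging that group for fluoro gave a 1.1-fold lower number from compound 2 to compound 3 (0.04 log units; within the scatter). All three stayed within the scatter, so no change beyond the scatter is expected in this assay, and no direction is favoured. The estimated step is a 1.1-fold lower number from compound 3 to compound 4 (0.02 log units; within the scatter). For compound 4 the expected value is 2000 nM, with an estimated range from 900 nM to 4500 nM.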

Compound 4, half-maximal inhibitory concentration: > 10000 nM
Compound 4 ended at the assay's limit (the forecaster's own chance of this, stated with the estimate: 3%); at least 5.0-fold (0.69 log units) between middle value and limit.
By their numbers in this assay, from the lowest: compounds 1, 3 and 2 (each within the scatter of the next). At a limit, above all of these: compound 4.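

In this assay compound 4 stands at a limit of the assay and not at a number: the limit of > 10000 nM in this assay, at which 1 of the 4 values shown sits.

Hydrogen, fluoro and (isobutylcarbonyl)oxy on this aromatic carbon had given numbers within the scatter of one another, whereas cyano is the first group shown here to give a step beyond it: an at least 4.7-fold higher number from compound 3 to compound 4 (0.67 log units; beyond the scatter), an at least 4.3-fold higher number from compound 2 to compound 4 (0.63 log units; beyond the scatter) and an at least 5.2-fold higher number from compound 1 to compound 4 (0.72 log units; beyond the scatter). Among the four groups shown, this position therefore separates only cyano from the rest.

Going by these compounds, how far compound 4 lies past the limit stays unknown, so the full size of these steps cannot be read. On these data alone, whether an amine, a carboxylic acid or a primary amide on this aromatic carbon would follow cyano or stay with the other three groups remains open.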